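This account rests on a few compounds, and the source may have more. Where it says the series, first, only, none or still open, it means among the compounds named here.

Measured compounds:
compound 1, `C=CCNc1nc(N)c(C(=O)N=C(N)N)nc1Cl`, 78%
compound 2, `CCCN(C)c1nc(N)c(C(=O)N=C(N)N)nc1Cl`, 91%
compound 3, `CN1CCN(c2nc(N)c(C(=O)N=C(N)N)nc2Cl)CC1`, 51%

In an assay for inhibition of acid-sensing ion channel 3 (Homo sapiens), read by patch clamp, tested at 20 uM (a lower number here means less inhibition, a higher number more inhibition at the concentration tested (going by the name of the read-out)), compound 3 stands lowest of the three: the steps of a number 27 percentage points lower from compound 1 to compound 3 (beyond the scatter) and a number 40 percentage points lower from compound 2 to compound 3 (beyond the scatter) both run downward, the first modest and the second large. Compound 4, `NC(N)=NC(=O)c1nc(Cl)c(Nc2ccccc2)nc1N`, differs from compound 3 by anilino in place of 4-methylpiperazin-1-yl on an aromatic carbon. For the measured compounds named here, no measured step covers the anilino group itself; the two steps toward compound 3 only show that the number for 4-methylpiperazin-1-yl is the lowest of the three, so the numbers for the other two groups tried are higher. Compound 4 is therefore expected to move upward, a number 19 percentage points higher from compound 3 to compound 4 (beyond the scatter), and its estimated value in this assay is 70%, with a range from 45% to 90%.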

Compound 4, a percentage reported as inhibition, at one concentration (the size of the read-out at that concentration, not a potency): 95%
Compound 4: middle estimate off by 25 percentage points, on the low side; the whole stated range lies below it.
By their numbers in this assay, from the lowest: compound 3; then compound 1; then compounds 2 and 4 (each within the scatter of the next).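

In this assay, the position on the aromatic carbon next to the ring nitrogen also accepts an aromatic ring: anilino gives a number 44 percentage points higher from compound 3 to compound 4 (beyond the scatter), and phenyl in place of allyl on the nitrogen gives a number 17 percentage points higher from compound 1 to compound 4 (beyond the scatter). Against methyl(propyl)amino the change gives a number 4 percentage points higher from compound 2 to compound 4 (within the scatter), so a high number here does not require an open chain. Nothing available accounts for these differences. From the compounds shown here alone, whether benzylamino or a chloro group on the phenyl ring would keep the number stays open. So does whether the low number of compound 3 belongs to its ring or to its second nitrogen, which piperidin-1-yl could separate.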